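Swapping a nitro for a chloro on the outer ring

The source may hold more compounds than are shown below. What is called first, only, known or untested is meant among the compounds shown, and "the series" means these compounds.

Of the compounds shown here, three built on one shared core have been measured in a functional assay on the whole organism (strain Wistar) with Rattus norvegicus as the target, with a stated time of 15 days, at a dose of 3 mg/kg by the oral route; a higher number here means a stronger effect of the compound at the dose given, a lower number a weaker effect. Compound 1 `O=C1NC(=O)/C(=C/c2ccc(OCCSc3nnc(-c4ccccc4)[nH]3)cc2)S1` gives 18.6%. Compound 2 `O=C1NC(=O)/C(=C/c2ccc(OCCSc3nnc(Cc4ccccc4)[nH]3)cc2)S1` gives 22.5%. Compound 3 `O=C1NC(=O)/C(=C/c2ccc(OCCSc3nnc(-c4ccc([N+](=O)[O-])cc4)[nH]3)cc2)S1` gives 14.1%. Compound 3 has the smallest of the three numbers, but the step of a number 4.5 percentage points lower from compound 1 to compound 3 (within the scatter) and the step of a number 8.4 percentage points lower from compound 2 to compound 3 (within the scatter) both sit within the scatter, so the three compounds cannot be told apart on these numbers.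

The next compound, compound 4 `O=C1NC(=O)/C(=C/c2ccc(OCCSc3nnc(-c4ccc(Cl)cc4)[nH]3)cc2)S1`, differs from compound 3 in one place: chloro in place of nitro on an aromatic carbon.

Among the compounds with values here, no measured step exchanges one substituent for another on this outer ring, so no step speaks to the chloro directly. The nearest is the step of a number 4.5 percentage points lower from compound 1 to compound 3 (within the scatter), which shows that putting a nitro onto the bare phenyl ring changed the activity by less than the scatter. The step of a number 3.9 percentage points higher from compound 1 to compound 2 (within the scatter) likewise stayed within the scatter. Taking the nitro away again and placing a chloro there is therefore expected to move the number little in this assay , with no direction beyond the scatter. The expected step is a number 3.9 percentage points higher from compound 3 to compound 4 (within the scatter). Compound 4 is estimated at 18%, with a likely range from 9% to 28%.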

Compound 4, a percentage reported as activity, at one dose (the size of the read-out at that dose, not a potency): 23.9%
For compound 4 the middle estimate is 5.9 percentage points below the measured one; the range from low to high includes it.
By their numbers in this assay, from the lowest: compounds 3, 1, 2 and 4 (each within the scatter of the next).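

Placing a chloro on the outer ring where the nitro stood gives the largest step seen so far in this assay, a number 9.8 percentage points higher from compound 3 to compound 4 (within the scatter), yet even this exchange does not separate the two compounds. The comparisons with the other two groups at this place on the shared core are no clearer: replacing hydrogen with chloro gives a number 5.3 percentage points higher from compound 1 to compound 4 (within the scatter), and the change from benzyl to 4-chlorophenyl gives a number 1.4 percentage points higher from compound 2 to compound 4 (within the scatter), so all four compounds remain indistinguishable on these numbers. Nothing available here offers an explanation for the numbers at this position.

The compounds shown leave open whether any group on this ring can move the activity clearly beyond the scatter, for example an amine, a carboxylic acid, a methoxy or a longer chain. Because each compound is represented by a single read-out at one dose, they also leave open how the compounds would compare at other doses.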